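This account rests on a few compounds, and the source may have more. Where it says the series, first, only, none or still open, it means among the compounds named here.

Compound 1 `CN1C(=O)C(c2ccc(F)cc2)N(C)c2nc(Nc3ccc(S(N)(=O)=O)cc3)ncc21` carries 4-fluorophenyl on a saturated ring carbon of the shared core, compound 2 `CN1C(=O)C(c2cccc(C(F)(F)F)c2)N(C)c2nc(Nc3ccc(S(N)(=O)=O)cc3)ncc21` carries 3-(trifluoromethyl)phenyl there, and compound 3 `Cc1ccc(F)cc1C1C(=O)N(C)c2cnc(Nc3ccc(S(N)(=O)=O)cc3)nc2N1C` carries 5-fluoro-2-methylphenyl. In an assay on Sf9 cells for inhibition of serine/threonine-protein kinase 4 (Homo sapiens), read by luminescence and ADP-Glo, with a stated time of 1 h, in the presence of a further agent that is not named here (a higher number here means a weaker inhibitor, a lower number a stronger inhibitor), compound 1 gives 1770 nM and compound 2 gives 2710 nM, a step of a 1.5-fold higher number from compound 1 to compound 2 (0.18 log units; within the scatter). Compound 3 gives 168 nM, the lowest of the three numbers; the steps to it are an 11-fold lower number from compound 1 to compound 3 (1.02 log units; beyond the scatter) and a 16-fold lower number from compound 2 to compound 3 (1.21 log units; beyond the scatter).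

Compound 4 `Cc1c(F)cccc1C1C(=O)N(C)c2cnc(Nc3ccc(S(N)(=O)=O)cc3)nc2N1C` is built from compound 3 by the change (3-fluoro-2-methylphenyl in place of 5-fluoro-2-methylphenyl on a saturated ring carbon); the two have the same atoms, joined differently. Among the measured compounds shown here, no measured step changes only the placing of the fluorine on an aryl ring that also bears a methyl: the steps from compound 1 and from compound 2 to compound 3 exchange the whole aryl group, and both are large. They show that the 5-fluoro-2-methylphenyl of compound 3 stands apart from the other two aryl groups, but not how much of that gap rests on the fluorine alone. A moderate rise in the number in this assay is therefore expected, with a wide range. Compound 4 is estimated at 350 nM, range 100 nM to 1300 nM. The expected step is a 2.1-fold higher number from compound 3 to compound 4 (0.32 log units; beyond the scatter).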

Compound 4, half-maximal inhibitory concentration: 419 nM
The estimate for compound 4 lay 1.2-fold (0.08 log units) below the measured number; measured number inside the range.
By their numbers in this assay, from the lowest: compound 3; then compound 4; then compounds 1 and 2 (each within the scatter of the next).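

Moving the fluorine while keeping the same atoms has a measurable effect at this saturated ring carbon: in this assay, the change to 3-fluoro-2-methylphenyl gives a 2.5-fold higher number from compound 3 to compound 4 (0.40 log units; beyond the scatter), so the placing of the fluorine on the methyl-bearing aryl ring matters on its own. Even so, the two aryl groups that bear a methyl both stand apart from 4-fluorophenyl and 3-(trifluoromethyl)phenyl, since the new group gives a 4.2-fold lower number from compound 1 to compound 4 (0.63 log units; beyond the scatter) and a 6.5-fold lower number from compound 2 to compound 4 (0.81 log units; beyond the scatter), and this holds for both fluorine placings shown. Nothing available explains why either change shifts the number.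

The separate shares of the methyl and the fluorine remain open, as a 2-methylphenyl with no fluorine is not among the compounds shown. On these data alone, whether chlorine or a methoxy group could stand in place of the fluorine also remains open.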